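The source may hold more compounds than are shown below. What is called first, only, known or untested is meant among the compounds shown, and "the series" means these compounds.

Measured so far:
compound 1 `CCn1c(CN2CCN(C(=O)C3CC3)CC2)nc2ccccc21` — 20.8%
compound 2 `Cc1cccc(Cn2c(CN3CCN(C(=O)c4ccc(C(F)(F)F)cc4)CC3)nc3ccccc32)c1` — 22.9%

In an assay on isolated protein for inhibition of aldehyde dehydrogenase 1A1 (Homo sapiens), read by spectrophotometry, tested at 10 uM (on this read-out higher numbers stand for more inhibition at the one concentration tested (going by the name of the read-out) and lower numbers for less inhibition), compound 2 gives the higher of the two numbers, but its gap to compound 1 lies within the usual scatter, so the two read alike. Compound 3 `CC(=O)N1CCN(Cc2nc3ccccc3n2Cc2cccc(C)c2)CC1` is not yet measured; it differs from compound 2 by methyl in place of 4-(trifluoromethyl)phenyl on a carbonyl carbon. Going by the values given here, no measured pair shows this change, so its size is unknown. Since compound 1 with 20.8% and compound 2 with 22.9% sit close despite different groups on the carbonyl carbon, little is expected here. The step expected is a number 4.9 percentage points lower from compound 2 to compound 3 (within the scatter), no more than the scatter. Compound 3 is estimated at 18%, ranging 4% to 34%.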

Compound 3, a percentage reported as inhibition, at one concentration (the size of the read-out at that concentration, not a potency): 70.3%
Estimate against measurement, compound 3: 52.3 percentage points below; the whole stated range lies below it.
By their numbers in this assay, from the lowest: compounds 1 and 2 (each within the scatter of the next); then compound 3.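

In this assay, methyl in place of 4-(trifluoromethyl)phenyl on a carbonyl carbon gives a number 47.4 percentage points higher from compound 2 to compound 3 (beyond the scatter), so this position strongly affects inhibition. Compounds 1 and 2 differ in more than one place, so their close values could not isolate it. Nothing available accounts for the step. The compounds shown do not separate loss of the aromatic ring from loss of the trifluoromethyl. An unsubstituted phenyl or an ethyl on the same carbonyl carbon would help tell these apart.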